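The compounds below may be only part of what the source reports. "The series", "measured", "known", "first", "only" and "open" are said of these compounds alone.

Measured in a functional assay on MCF7 cells (Homo sapiens) for inhibition, read by sulforhodamine B assay; a higher number here means a weaker inhibitor, a lower number a stronger inhibitor:
- Compound 1 `O=C1C=C(NCc2ccccc2)C(=O)c2c1nc1n2[C@H]2OC[C@@H](O)[C@H]2OC1`: > 8000 nM, a limit
- Compound 2 `O=C1C=C(Nc2ccc(Br)cc2)C(=O)c2c1nc1n2[C@H]2OC[C@@H](O)[C@H]2OC1`: 2580 nM
- Compound 3 `O=C1C=C(Nc2ccc(C(F)(F)F)cc2)C(=O)c2c1nc1n2[C@H]2OC[C@@H](O)[C@H]2OC1`: > 4000 nM, a limit

Compound 3 has no exact number, and its reading of > 4000 nM is a limit. Only compound 2 has an exact value here, so the comparison has little to stand on.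

Compound 4 `COc1ccc(NC2=CC(=O)c3nc4n(c3C2=O)[C@H]2OC[C@@H](O)[C@H]2OC4)cc1` has methoxy in place of trifluoromethyl on an aromatic carbon, para to a large group: methoxy in place of trifluoromethyl on an aromatic carbon.

Among the measured compounds shown here, two measured steps bear on this change. The closest swaps a group at that same place, with trifluoromethyl in place of bromo on an aromatic carbon: an at least 1.5-fold higher number from compound 2 to compound 3 (0.19 log units; that floor lies within the scatter). That step sets only a floor, so it says little about how much this place matters. The other has 4-bromophenyl in place of benzyl on an amine nitrogen: an at least 3.1-fold lower number from compound 1 to compound 2 (0.49 log units; beyond the scatter). Compound 4 also carries a substituted phenyl on that nitrogen, as a 4-methoxyphenyl, so it should resemble compound 2, at 2580 nM, more than compound 1.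

A small move to a lower number is therefore expected, though the limit on compound 3 keeps its true size uncertain. The expected step is an at least 1.3-fold lower number from compound 3 to compound 4 (0.12 log units; that floor lies within the scatter). For compound 4 the estimated value is 3000 nM, with an expected range of 1200 nM to 7500 nM.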

Compound 4, half-maximal inhibitory concentration: 5420 nM
Compound 4: the middle estimate sits 1.8-fold (0.26 log units) below what was measured, and the stated range covers the measured number.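

In this assay, the group on the aromatic carbon now has its first step with exact numbers at both ends: methoxy in place of bromo gives a 2.1-fold higher number from compound 2 to compound 4 (0.32 log units; beyond the scatter), which shows that this place responds to a swap, though only modestly. Putting 4-methoxyphenyl in place of benzyl on the amine nitrogen gives an at least 1.4-fold lower number from compound 1 to compound 4 (0.16 log units; that floor lies within the scatter), and since that floor lies within the scatter, the clearer gain seen earlier with 4-bromophenyl is not shown to carry over to this second substituted phenyl. The direct swap of methoxy in place of trifluoromethyl cannot be read, because compound 3 has only a limit: the limit of > 4000 nM in this assay, at which 1 of the 4 values shown sits.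

With exact values for only compound 2 and compound 4, the compounds shown give no full order of bromo, trifluoromethyl and methoxy at this place, and they cannot say how far the reading would move with the true value of compound 3 in hand. They also leave open how an amine, a carboxylic acid or a simple chloro group would read on the same aromatic carbon.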